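Methyl in Place of Fluoro on the Sulfonyl Ring

A few compounds are considered here, and "the series" means these few. Any claim that something is new, unique, unknown or untested is made for them only; others in the source may bear on it.

Compound 1 `COc1cc(-c2nc(-c3ccccc3)[nH]c2-c2ccnc(NCCCNS(=O)(=O)c3ccc(Cl)cc3)n2)ccc1Cl`: 60900 nM
Compound 2 `COc1cc(-c2nc(-c3ccccc3)[nH]c2-c2ccnc(NCCCNS(=O)(=O)c3ccc(F)cc3)n2)ccc1Cl`: 4530 nM

Both compounds share one core and were tested in a functional assay on LOX IMVI cells (Homo sapiens) for cytotoxicity, read by MTT assay, with a stated time of 24 h; a higher number here means a weaker inhibitor, a lower number a stronger inhibitor. Among the measured compounds shown here, compound 2 holds the lowest of the two numbers; its only neighbour is compound 1, and the step between them, a 13-fold lower number from compound 1 to compound 2 (1.13 log units; beyond the scatter), is large and lies well beyond the scatter. For the measured compounds named here, that step is the sole measured comparison here, and it concerns only the exchange of chloro for fluoro on the aromatic carbon of the sulfonyl-bearing ring.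

Compound 3 `COc1cc(-c2nc(-c3ccccc3)[nH]c2-c2ccnc(NCCCNS(=O)(=O)c3ccc(C)cc3)n2)ccc1Cl` has not yet been measured. It differs from compound 2 by methyl in place of fluoro on an aromatic carbon. Going by the values given here, no measured step carries the methyl group itself, so the only guide is that the one change made at this same place, from compound 1 to compound 2, shifted the number by a large amount. The same position is therefore expected to matter again, and the number for compound 3 is expected to move back up toward compound 1, as a 3.3-fold higher number from compound 2 to compound 3 (0.52 log units; beyond the scatter). Compound 3 is estimated at 15000 nM, within a range from 4000 nM to 55000 nM.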

Compound 3, half-maximal inhibitory concentration: 18600 nM
Compound 3: the middle estimate sits 1.2-fold (0.09 log units) below what was measured, and the stated range covers the measured number.
By their numbers in this assay, from the lowest: compound 2; then compound 3; then compound 1.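

In this assay, methyl in place of fluoro gives a 4.1-fold higher number from compound 2 to compound 3 (0.61 log units; beyond the scatter), and methyl in place of chloro gives a 3.3-fold lower number from compound 1 to compound 3 (0.52 log units; beyond the scatter), so the methyl compound falls between the other two and matches neither. The earlier pair showed only that this carbon responds to one exchange; with a third group, all three compounds are now separated beyond the scatter, and the fluoro compound still holds the lowest number. The change from fluoro to methyl also leaves the heavy-atom count, the hydrogen-bond donor and acceptor counts and the net charge as they were, so these counts alone do not tell the two compounds apart, and nothing available here explains why the three groups fall in this order.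

The compounds shown leave open where a methoxy, a nitrile or an amine on this same carbon would fall, and whether any such group would give a lower number than compound 2 does. They also leave open whether fluoro, methyl and chloro would keep this order with a longer chain linking the sulfonyl group to the shared core.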